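From Hydroxy to Methoxy: One Change on Compound 2

The source may report more compounds than this note shows. Statements on the series, on what has been measured and on what is new or still open speak of the compounds shown alone.

Compound 1, `Cn1cc(/C=C2\C(=O)Nc3ccc(S(N)(=O)=O)cc32)c2ccccc21`, gives 116% in an assay on isolated protein for inhibition of SRSF protein kinase 1 (Homo sapiens), tested at 0.1 uM; on this read-out lower numbers stand for a stronger effect and higher numbers for a weaker effect at the one concentration tested.
Compound 2, `CN(C)S(=O)(=O)c1ccc2c(c1)/C(=C/c1cn(C)c3ccc(O)cc13)C(=O)N2`, gives 109% in this assay.

Only these two compounds have been measured so far, and neither shows any inhibition in this assay. Compound 2 has the smaller of the two numbers, but the gap to compound 1 lies within the usual scatter of repeated measurements, so the two stand as equals on this read-out.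

Compound 3, `COc1ccc2c(c1)c(/C=C1\C(=O)Nc3ccc(S(=O)(=O)N(C)C)cc31)cn2C`, is the next compound in line. It differs from compound 2 in one place only: methyl in place of hydrogen on an oxygen on an aromatic ring. Within the data shown here, no measured pair in this small set carries the same change, so there is no precedent to lean on.

Given that compound 2 shows no inhibition, the expectation for compound 3 is a step in this assay of a number 1 percentage points higher from compound 2 to compound 3 (within the scatter), that is, nothing beyond the scatter in either direction. On that basis compound 3 is expected to give about 110%, with a likely range from 95% to 125%.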

Compound 3, a percentage reported as activity, at one concentration (the size of the read-out at that concentration, not a potency): 111%
For compound 3 the middle estimate is 1 percentage points below the measured one; measured number inside the range.
By their numbers in this assay, from the lowest: compounds 2, 3 and 1 (each within the scatter of the next).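

The change from hydroxy to methoxy brings a number 2 percentage points higher from compound 2 to compound 3 (within the scatter) in this assay and so leaves the read-out where it stood. Among these compounds, this is the first pair in the set that differs in one place only, and it shows that putting methyl in place of the hydrogen on this oxygen does not bring out any inhibition at the one concentration tested. Compound 2 showed no inhibition to begin with, however, so the pair cannot tell whether this position matters in a compound that does inhibit, and nothing at hand bears on why the result is flat.

The compounds shown leave open whether a larger group on this oxygen, such as a longer chain ending in an amine or a carboxylic acid, would move the read-out at all. They also leave open whether the change from hydroxy to methoxy would make any difference at a higher concentration, where a read-out with room to fall might separate compound 2 and compound 3.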